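Moving the Chlorine Around the Ring

The source may hold more compounds than are shown below. What is called first, only, known or untested is meant among the compounds shown, and "the series" means these compounds.

For the measured compounds named here, compound 3 `O=C1CSC(c2ccccc2Cl)N1CCN1CCCCC1` was tested in an ADME assay on Vero cells (Chlorocebus sabaeus) for cytotoxicity, read by neutral red uptake, tested at 197 ug/mL (on this read-out higher numbers stand for a weaker effect at the one concentration tested and lower numbers for a stronger effect), and gave 71%, the lowest of the three numbers measured so far. Compound 1 `COc1ccc(C2SCC(=O)N2CCN2CCCCC2)cc1` gives 87% in this assay, and compound 2 `O=C1CSC(c2ccc(O)cc2)N1CCN1CCCCC1` gives 87%. Between those two, no change at the digits printed from compound 1 to compound 2 (within the scatter), so replacing methyl with hydrogen on the ring oxygen left the two compounds level. The only visible shift came with a number 16 percentage points lower from compound 2 to compound 3 (beyond the scatter), where a 4-hydroxyphenyl gave way to a 2-chlorophenyl. Compound 4 `O=C1CSC(c2ccc(Cl)cc2)N1CCN1CCCCC1` has not yet been measured. It differs from compound 3 in one respect: 4-chlorophenyl in place of 2-chlorophenyl on a saturated ring carbon. Neither measured step moves a chlorine from one spot to another on the same ring, so there is no direct guide for this change. The steps seen so far were either within the scatter or modest, which suggests a step of similar size at most, more likely upward toward the numbers of compound 1 and compound 2, as compound 3 already holds the lowest reading, 71%. For compound 4 the expected step is a number 7 percentage points higher from compound 3 to compound 4 (within the scatter). The estimate for compound 4 in this assay is 78%, with a likely range from 65% to 92%.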

Compound 4, a percentage reported as activity, at one concentration (the size of the read-out at that concentration, not a potency): 68%
The estimate for compound 4 lay 10 percentage points above the measured number; the range from low to high includes it.
By their numbers in this assay, from the lowest: compounds 4 and 3 (each within the scatter of the next); then compounds 1 and 2 (each within the scatter of the next).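

Within this assay, moving the chlorine gave a number 3 percentage points lower from compound 3 to compound 4 (within the scatter), so the 2-chlorophenyl and 4-chlorophenyl groups cannot be told apart on this saturated ring carbon, something no earlier step could test. The other two new steps are a number 19 percentage points lower from compound 2 to compound 4 (beyond the scatter) for chloro in place of hydroxy and a number 19 percentage points lower from compound 1 to compound 4 (beyond the scatter) for chloro in place of methoxy, which separates two things that changed together on the way from compound 2 to compound 3: swapping the group on the aromatic ring goes with a shift in the read-out, while relocating the chlorine does not, and none of these four compounds goes against that split. Nothing available here explains why the chloro compounds give the lower numbers in this cell test.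

Going by these compounds, it remains open whether this belongs to chlorine specifically or would also appear with fluoro, bromo, methyl or an unsubstituted phenyl ring, and whether an amine or a carboxylic acid on the ring would move the number the other way. Every compound shown also carries the same piperidine-bearing ethyl chain, so what a shorter or longer chain would do at this concentration is unknown as well.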